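Working notes: replacing the piperazine of compound 1

This account rests on a few compounds, and the source may have more. Where it says the series, first, only, none or still open, it means among the compounds named here.

Measured in a functional assay on HCC827 cells (Homo sapiens) for antiproliferative activity, read by MTT assay, with a stated time of 72 h; on this read-out lower numbers stand for stronger inhibition and higher numbers for weaker inhibition
compound 1 `CN1CCN(c2ccc(Nc3ncc4nc(Sc5ccccc5)n(C5CCOCC5)c4n3)cc2)CC1` gives 42.6 nM
compound 2 `CN1CCN(c2ccc(Nc3ncc4nc(Sc5ccccc5)n(C5CCCC5)c4n3)cc2)CC1` gives 51.2 nM

Compound 1 has a single measured neighbour, and neither compound stands apart: the step is a 1.2-fold higher number from compound 1 to compound 2 (0.08 log units; within the scatter). That step, cyclopentyl in place of oxan-4-yl on an aromatic nitrogen, lies elsewhere on the molecule. Compound 3 `CN1CCC(Oc2ccc(Nc3ncc4nc(Sc5ccccc5)n(C5CCOCC5)c4n3)cc2)CC1` differs from compound 1 by (1-methylpiperidin-4-yl)oxy in place of 4-methylpiperazin-1-yl on an aromatic carbon, with (1-methylpiperidin-4-yl)oxy in place of 4-methylpiperazin-1-yl on an aromatic carbon. For the measured compounds named here, no measured step covers this change, so no shift beyond the scatter is expected in this assay, though the uncertainty is wide. The estimated step is a 1.4-fold higher number from compound 1 to compound 3 (0.15 log units; within the scatter). For compound 3 the expected value is 60 nM, with an estimated range of 20 nM to 170 nM.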

Compound 3, half-maximal inhibitory concentration: 140 nM
The estimate for compound 3 lay 2.3-fold (0.37 log units) below the measured number, and the stated range covers the measured number.
By their numbers in this assay, from the lowest: compounds 1 and 2 (each within the scatter of the next); then compound 3.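

This position is sensitive in this assay: (1-methylpiperidin-4-yl)oxy in place of 4-methylpiperazin-1-yl gives a 3.3-fold higher number from compound 1 to compound 3 (0.52 log units; beyond the scatter), whereas the earlier change on the aromatic nitrogen, a 1.2-fold higher number from compound 1 to compound 2 (0.08 log units; within the scatter), stayed within the scatter. The entering group keeps a six-membered non-aromatic ring and the same count of hydrogen-bond acceptors, yet the number still rises. No measured evidence bears on the reason for this step.

Still open, as far as these compounds go, is which part of the replacement carries the step, the ether oxygen or the altered ring. Also open, from the compounds shown here alone, is whether a morpholin-4-yl group or a piperidine joined through an amine at this carbon would stay close to compound 1.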